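The compounds below may be only part of what the source reports. "The series", "measured", "known", "first", "only" and "open" are said of these compounds alone.

Compound 1 `CC(C)c1cccc(NC(=O)N[C@@H](C)c2ccccc2)c1` gives 95% in an ADME assay on the whole organism with Oryza sativa as the target, tested at 0.1 uM; on this read-out higher numbers stand for a weaker effect at the one concentration tested and lower numbers for a stronger effect. Compound 2 `C[C@H](NC(=O)Nc1cccc(C(F)(F)F)c1)c1ccccc1` gives 94% in this assay.

For the measured compounds named here, compound 2 and compound 1 sit within the scatter of each other, the only step so far being a number 1 percentage points lower from compound 1 to compound 2 (within the scatter). Compound 3 `CCOC(=O)c1cccc(NC(=O)N[C@@H](C)c2ccccc2)c1` differs from compound 2 by ethoxycarbonyl in place of trifluoromethyl on an aromatic carbon. Going by the values given here, no measured step carries this change; the one step at the same place, a number 1 percentage points lower from compound 1 to compound 2 (within the scatter), stayed within the scatter. The expected step in this assay is therefore a number 2 percentage points lower from compound 2 to compound 3 (within the scatter), none beyond the scatter. Compound 3 is estimated at 92%, with a range of 80% to 100%.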

Compound 3, a percentage reported as activity, at one concentration (the size of the read-out at that concentration, not a potency): 100%
Estimate against measurement, compound 3: 8 percentage points below; measured number inside the range.
By their numbers in this assay, from the lowest: compounds 2, 1 and 3 (each within the scatter of the next).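

On an aromatic carbon meta to a large group, the change to ethoxycarbonyl gives a number 6 percentage points higher from compound 2 to compound 3 (within the scatter) and a number 5 percentage points higher from compound 1 to compound 3 (within the scatter), so the read-out has now stayed within the scatter across three different groups at this place. Ethoxycarbonyl enters with 2 hydrogen-bond acceptors where trifluoromethyl has 0, and this difference brings no step beyond the scatter. No measurement is at hand to account for these numbers.
On these data alone, whether an amine or a carboxylic acid at this place would give a step beyond the scatter stays open. So does the effect of changes elsewhere on the shared core.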